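The source may report more compounds than this note shows. Statements on the series, on what has been measured and on what is new or still open speak of the compounds shown alone.

Measured in an assay on CHO cells for displacement of a labelled ligand from adenosine receptor A3 (Homo sapiens), read by scintillation counting, with a stated time of 3 h; on this read-out lower numbers stand for stronger inhibition and higher numbers for weaker inhibition:
compound 1 `Cn1c(-c2ccccc2)nc2c(NC3CCCCC3)ncnc21` — 2370 nM
compound 2 `Cn1c(-c2ccccc2)nc2c(NC3CCC3)ncnc21` — 280 nM
compound 3 `Cn1c(-c2ccc(Cl)cc2)nc2c(NC3CCCC3)ncnc21` — 1210 nM

In this assay compound 3 stands second highest of the three numbers; its value and that of compound 1 lie within the scatter of each other, while compound 2 sits at a lower number beyond the scatter. Compound 4 `Cn1c(-c2ccccc2)nc2c(NC3CCCC3)ncnc21` differs from compound 3 by hydrogen in place of chloro on an aromatic carbon, on an aromatic carbon of a six-membered aromatic ring of carbon only; cut one bond further out, 4-chlorophenyl becomes phenyl. Among the measured compounds shown here, the single measured step, an 8.5-fold lower number from compound 1 to compound 2 (0.93 log units; beyond the scatter), concerns the ring on the nitrogen and not this position, so no measured step bears on the change from chloro to hydrogen. Compound 2 and compound 3 differ in two places at once and do not isolate it either. With nothing to support a shift in either direction, the expected step of a 1.2-fold lower number from compound 3 to compound 4 (0.08 log units; within the scatter) is none beyond the scatter, with wide uncertainty. Compound 4 is therefore estimated at 1000 nM, range 300 nM to 3000 nM.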

Compound 4, inhibition constant: 846 nM
Estimate against measurement, compound 4: 1.2-fold (0.07 log units) above, and the stated range covers the measured number.
By their numbers in this assay, from the lowest: compound 2; then compounds 4, 3 and 1 (each within the scatter of the next, the first and the last beyond it).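

In this assay, the change from 4-chlorophenyl to phenyl reads as (a 1.4-fold lower number from compound 3 to compound 4 (0.16 log units; within the scatter)), so with cyclopentyl on the nitrogen this position does not tell chloro from hydrogen. Compound 4 also adds the middle member of the ring series on the nitrogen (a 3.0-fold higher number from compound 2 to compound 4 (0.48 log units; beyond the scatter); a 2.8-fold lower number from compound 1 to compound 4 (0.45 log units; beyond the scatter)), so the number rises from cyclobutyl through cyclopentyl to cyclohexyl across these three compounds, with none among them going against it. No available evidence bears on either result.

Still open, from the compounds shown here alone, is whether chloro and hydrogen stay within the scatter of each other with cyclobutyl on the nitrogen, and what an amine or a carboxylic acid would give on the same aromatic carbon. Also open, going by these compounds, is whether the rise continues to hold with cyclopropyl or a longer open chain on the nitrogen.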